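The compounds below may be only part of what the source reports. "The series", "measured", "known", "first", "only" and "open" are said of these compounds alone.

Compound 1, `CC(c1c(F)cc2ncc(-c3cnn(C)c3)cc2c1F)n1nnc2ncc(-c3ccc(C(N)=O)c(F)c3)nc21`, is the anchor of this series: in a functional assay on NCI-H1993 cells (Homo sapiens) for inhibition, read by CCK-8 assay, with a stated time of 72 h (a higher number here means a weaker inhibitor, a lower number a stronger inhibitor), compound 1 gives 0.4 nM, a strongly potent result. Compound 2, `CNC(=O)c1ccc(-c2cnc3nnn(C(C)c4c(F)cc5ncc(-c6cnn(C)c6)cc5c4F)c3n2)cc1F`, carries the closely related 3-fluoro-4-(methylcarbamoyl)phenyl group, yet in this assay compound 2 stands at "not determined" (no result reported), so there is no single number from which to step. Compound 3, `CC(c1c(F)cc2ncc(-c3cnn(C)c3)cc2c1F)n1nnc2ncc(-c3ccncc3)nc21`, is the next compound to be measured; it differs from compound 2 by pyridin-4-yl in place of 3-fluoro-4-(methylcarbamoyl)phenyl on an aromatic carbon. With no number for compound 2, the expected step can only be set against compound 1. The pyridin-4-yl group brings no hydrogen-bond donor where the departing group had one, and the reading for compound 3 is therefore expected to fall somewhat weaker than compound 1 at 0.4 nM, by a step beyond the usual scatter but not a large one. Compound 3 is estimated to give about 3 nM in this assay, with a likely range from 0.5 nM to 20 nM.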

Compound 3, half-maximal inhibitory concentration: 0.2 nM
For compound 3 the middle estimate is 15-fold (1.18 log units) above the measured one, outside the stated range (below it).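

In this assay, the step of a 2.0-fold lower number from compound 1 to compound 3 (0.30 log units; within the scatter) comes from putting pyridin-4-yl in place of 4-carbamoyl-3-fluorophenyl on an aromatic carbon of the six-membered aromatic ring with 2 nitrogen, and it shows that this position accepts two quite different groups with no change in the reading beyond the scatter. Neither the carbamoyl group nor the fluorine of compound 1 is present in compound 3, so within this pair, potency in this assay does not depend on either of them or on the benzene ring that carries them. The data give no measured basis for explaining why the two readings match.

The step from compound 2 to compound 3 cannot be read, leaving the effect of the methyl group on the amide nitrogen of compound 2 unknown. Going by these compounds, it also remains open whether the ring nitrogen of pyridin-4-yl matters at this position, and how the reading would respond to a plain phenyl group, a pyridin-3-yl group, a carboxylic acid on the phenyl ring or a morpholine ring in its place.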